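A Thioether Added to the Core of a Weak Inhibitor

This account rests on a few compounds, and the source may have more. Where it says the series, first, only, none or still open, it means among the compounds named here.

Compound 1 `COc1cccc(Sc2c(/C=C/[C@@H]3C[C@@H](O)CC(=O)O3)c(C3CC3)nc3cc(F)c(F)cc23)c1` holds the lower of the two numbers in an assay on isolated protein for inhibition of 3-hydroxy-3-methylglutaryl-coenzyme A reductase (Homo sapiens), read by spectrophotometry (on this read-out higher numbers stand for weaker inhibition and lower numbers for stronger inhibition), where compound 1 gives 360000 nM. Compound 2 `CC(C)c1ccc(Sc2c(/C=C/[C@@H]3C[C@@H](O)CC(=O)O3)c(C3CC3)nc3cc(F)c(F)cc23)cc1` gives 759000 nM in this assay. Within the data shown here, the only measured step, a 2.1-fold higher number from compound 1 to compound 2 (0.32 log units; beyond the scatter), changed the group on the sulfur. Compound 3 `COc1cccc(Sc2cc3nc(C4CC4)c(/C=C/[C@@H]4C[C@@H](O)CC(=O)O4)c(Sc4cccc(OC)c4)c3cc2F)c1` differs from compound 1 at another place: (3-methoxyphenyl)sulfanyl in place of fluoro on an aromatic carbon. Among the measured compounds shown here, no measured step touches that position, so the direction is open and the measured step offers no direct guide. Compound 3 is expected to give about 500000 nM, between 150000 nM and 2000000 nM. That expectation amounts to a step of a 1.4-fold higher number from compound 1 to compound 3 (0.14 log units; within the scatter).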

Compound 3, half-maximal inhibitory concentration: 7100 nM
For compound 3 the middle estimate is 70-fold (1.85 log units) above the measured one; the whole stated range lies above it.
By their numbers in this assay, from the lowest: compound 3; then compound 1; then compound 2.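

In this assay, (3-methoxyphenyl)sulfanyl in place of fluoro on an aromatic carbon gave a 51-fold lower number from compound 1 to compound 3 (1.71 log units; beyond the scatter), a far larger step than the change on the existing sulfur, a 2.1-fold higher number from compound 1 to compound 2 (0.32 log units; beyond the scatter). This aromatic carbon, ortho to a fluoro group, therefore tolerates a group of 9 heavy atoms in place of a single fluorine, and the number falls sharply. Nothing available explains this drop. The compounds shown leave open whether the step depends on the sulfur or on the 3-methoxyphenyl ring, and whether an amine or a short alkyl chain on this carbon would give a similar number.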